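Arylsulfonyl exchange in the indoline amide series

This account rests on a few compounds, and the source may have more. Where it says the series, first, only, none or still open, it means among the compounds named here.

Three measured compounds share one core and differ in the aryl group on the sulfonyl sulfur and in the amine of the amide. Compound 1 `COc1ccc(S(=O)(=O)N2CC(C(=O)NC3CCN(Cc4ccccc4)CC3)c3ccccc32)c2ccccc12` gives 50.1 nM in a functional assay on CHO cells for antagonist activity at 5-hydroxytryptamine receptor 6 (Homo sapiens), read by FLIPR; a higher number here means a weaker inhibitor, a lower number a stronger inhibitor. Compound 2 `CCN(CC)CCCNC(=O)C1CN(S(=O)(=O)c2ccc(OC)c3ccccc23)c2ccccc21` gives 79.4 nM in this assay. Compound 3 `CN1CCC(N(C)C(=O)C2CN(S(=O)(=O)c3cccc4c(Cl)cccc34)c3ccccc32)CC1` gives 5.01 nM in this assay, the lowest of the three numbers, beyond the scatter from compound 1 and from compound 2.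

Compound 4 `Cc1c(S(=O)(=O)N2CC(C(=O)N(C)C3CCN(C)CC3)c3ccccc32)sc2ccc(Cl)cc12` is not yet measured. It differs from compound 3 in one place: 5-chloro-3-methyl-1-benzothiophen-2-yl in place of 5-chloronaphthalen-1-yl on a sulfonyl sulfur. Going by the values given here, no measured pair in this set shows that change alone, so the size of the step is not known from the data. The expectation for compound 4 is a small step from compound 3, if any, leaning toward a weaker inhibitor and close to the edge of the scatter, estimated as a 2.0-fold higher number from compound 3 to compound 4 (0.30 log units; within the scatter). Compound 4 is therefore expected to give about 10 nM in this assay, within a range from 2.5 nM to 40 nM.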

Compound 4, inhibition constant: 63.1 nM
Estimate against measurement, compound 4: 6.3-fold (0.80 log units) below; the whole stated range lies below it.
By their numbers in this assay, from the lowest: compound 3; then compounds 1, 4 and 2 (each within the scatter of the next).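

Going by these compounds alone, with the amide and the shared core held constant, the sulfonyl aryl group is isolated for the first time: in this assay, 5-chloro-3-methyl-1-benzothiophen-2-yl in place of 5-chloronaphthalen-1-yl gives a 13-fold higher number from compound 3 to compound 4 (1.10 log units; beyond the scatter) and this is a large step. The position on the sulfonyl sulfur therefore discriminates between these two chlorinated fused aromatic groups, even though their heavy-atom counts match. Nothing available accounts for the size of this step.

Going by these compounds, it remains open whether the step follows from the ring exchange or from the methyl group, a question that 5-chloro-1-benzothiophen-2-yl on the amide of compound 3 would address. Also open, on these data alone, is whether the same exchange gives a step of similar size with the benzylpiperidine amide of compound 1.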